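The source may report more compounds than this note shows. Statements on the series, on what has been measured and on what is new or still open speak of the compounds shown alone.

Measured compounds:
- compound 1, `O=C1N=C(N2N=C(c3ccccc3)CC2c2ccccc2O)S/C1=C1/C(=O)Nc2ccc(Br)cc21`: 230 nM
- compound 2, `COc1ccc(C2CC(c3ccccc3)=NN2C2=NC(=O)/C(=C3\C(=O)Nc4ccc(Br)cc43)S2)cc1`: 210 nM

Both compounds share one core and were tested in a functional assay on cells (Melanoma cell, Homo sapiens) for cytotoxicity, read by sulforhodamine B assay, with a stated time of 48 h; a lower number here means a stronger inhibitor of growth, a higher number a weaker inhibitor of growth. Compound 1 gives 230 nM there, and compound 2 gives 210 nM. Going by the values given here, the only measured step, a 1.1-fold lower number from compound 1 to compound 2 (0.04 log units; within the scatter), exchanged one group on a saturated ring carbon and left the number essentially unchanged. Compound 2 thus has the lowest of the two numbers, but its gap to compound 1 is within the scatter, so neither can be called the stronger inhibitor.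

Compound 3, `COc1ccc(C2CC(c3ccc4ccccc4c3)=NN2C2=NC(=O)/C(=C3\C(=O)Nc4ccc(Br)cc43)S2)cc1`, differs from compound 2 at another place: naphthalen-2-yl in place of phenyl on a carbon with a double bond to nitrogen. Among the compounds with values here, no measured step touches this position, so the known step between compound 1 and compound 2 says nothing direct about it; it only shows that one change elsewhere on the core was tolerated without any shift beyond the scatter. With no evidence for a step in either direction, the expectation for compound 3 in this assay is a number close to that of compound 2, with the step of a 1.1-fold lower number from compound 2 to compound 3 (0.02 log units; within the scatter) expected to lie within the scatter. Compound 3 is therefore estimated at 200 nM, with a range from 70 nM to 600 nM.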

Compound 3, concentration for 50% growth inhibition: 69 nM
For compound 3 the middle estimate is 2.9-fold (0.46 log units) above the measured one; the measured number lies below the stated range.
By their numbers in this assay, from the lowest: compound 3; then compounds 2 and 1 (each within the scatter of the next).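

In this assay the position on the carbon with a double bond to nitrogen proves to be one where a change can move the number: replacing phenyl with naphthalen-2-yl, which adds a second six-membered aromatic ring of carbon only and no hydrogen-bond donors or acceptors, gives a 3.0-fold lower number from compound 2 to compound 3 (0.48 log units; beyond the scatter) as a modest gain in growth inhibition. Going by these compounds alone, the earlier step, made at a different place on the shared core, stayed within the scatter, so this is the first sign in the set that a single change can shift the number beyond it, although it rests on one pair of compounds. No measurement shown here accounts for this step.

The compounds shown leave open whether naphthalen-2-yl would give a similar step alongside the 2-hydroxyphenyl group of compound 1 in place of the 4-methoxyphenyl group. They also leave open how this position would respond to a different group, such as a quinolin-2-yl ring, which carries a ring nitrogen, or a phenyl ring bearing an amine.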